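The compounds below may be only part of what the source reports. "The series", "measured", "known", "first", "only" and "open" are said of these compounds alone.

Of the compounds shown here, three have numbers so far in a functional assay on A549 cells (Homo sapiens) for antiproliferative activity, read by sulforhodamine B assay, with a stated time of 3 days; on this read-out higher numbers stand for an effect only at larger amounts of compound and lower numbers for an effect already at smaller amounts. Compound 1 `CCCC1=C(OC)C(CCC)(CCC)C(=O)/C(=C(O)\C=C\c2ccccc2)C1=O` gives 3.6 uM, compound 2 `CCCC1=C(OC)C(CCC)(CCC)C(=O)/C(=C(O)\C=C\c2ccc(I)cc2)C1=O` gives 1.4 uM, and compound 3 `CCCC1(CC=C(C)C)C(=O)C(C(=O)/C=C/c2ccccc2)=C(O)C(CCC)(CCC)C1=O` gives 7.1 uM. Compound 2 therefore holds the lowest of the three numbers, with compound 1 the nearest and compound 3 the furthest.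

The next entry is compound 4 `CCCC1=C(OC)C(CCC)(CCC)C(=O)/C(=C(O)\C=C\c2ccc(Br)cc2)C1=O`, and the change is bromo in place of iodo on an aromatic carbon, para to a large group. Within the data shown here, one measured step bears on this place: a 2.6-fold lower number from compound 1 to compound 2 (0.41 log units; beyond the scatter), modest and beyond the scatter, with iodo in place of hydrogen on an aromatic carbon. Among the measured compounds shown here, compound 3 offers no single-place step to either neighbour and adds nothing here. For the measured compounds named here, no bromo compound has a number yet, so a swap of one halogen for another has not been seen directly.

With a halogen still on the ring, only part of the modest hydrogen-to-iodo step is expected to be given back, and a change in the upward direction is the working assumption. The expected step is a 1.4-fold higher number from compound 2 to compound 4 (0.13 log units; within the scatter), which would stay within the scatter. Compound 4 is estimated at 1.9 uM, with an expected range of 0.9 uM to 3.8 uM.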

Compound 4, concentration for half-maximal effect: 2 uM
Compound 4: the middle estimate sits 1.1-fold (0.02 log units) below what was measured, within the range that was stated.
By their numbers in this assay, from the lowest: compounds 2, 4, 1 and 3 (each within the scatter of the next, the first and the last beyond it).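

In this assay, among these compounds, the first direct swap of one halogen for another on this aromatic carbon, para to a large group, gives a 1.4-fold higher number from compound 2 to compound 4 (0.15 log units; within the scatter) and so does not separate iodo from bromo on this read-out. Against the hydrogen of compound 1, bromo gives a 1.8-fold lower number from compound 1 to compound 4 (0.26 log units; within the scatter) while iodo gives a 2.6-fold lower number from compound 1 to compound 2 (0.41 log units; beyond the scatter) and only the iodo step lies beyond the scatter, so the two compounds shown do not support a general halogen effect at this place. Nothing at hand gives a reason for either step.

As far as these compounds go, whether this place accepts a group other than a halogen, such as methoxy, an amine or a carboxylic acid, stays open, as does the outcome with the smaller chloro or fluoro. Also open, from the compounds shown here alone, is whether the 4-iodophenyl or 4-bromophenyl group would carry over to the core of compound 3, which so far appears here only with an unsubstituted phenyl.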